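The compounds below may be only part of what the source reports. "The series", "measured", "known", "first", "only" and "open" are said of these compounds alone.

Measured so far:
Compound 1, `O=C(NO)c1ccc(Cn2nnc(-c3ccc(C(F)(F)F)cc3)n2)cc1`, gives 11 nM in an assay on Sf9 cells for inhibition of protein deacetylase HDAC6 (Homo sapiens), read by fluorescence; a higher number here means a weaker inhibitor, a lower number a stronger inhibitor.
Compound 2, `Cc1cc(-c2nnc(Sc3ccc(C(=O)NO)cc3)n2C)nn1C`, gives 5 nM in this assay.

Compound 1 holds the higher of the two numbers; compound 2 sits below it by a margin beyond the usual scatter. Compound 3, `Nc1ccc(-c2nnn(Cc3ccc(C(=O)NO)cc3)n2)cc1`, is not yet measured. Its difference from compound 1 is amino in place of trifluoromethyl on an aromatic carbon. Among the compounds with values here, no measured pair here tracks this change, so no direction can be read from a step; the expectation is a step from compound 1 to compound 3 of a 1.4-fold higher number from compound 1 to compound 3 (0.13 log units; within the scatter), within the usual scatter. Compound 3 is thus estimated at 15 nM, with a range from 5 nM to 45 nM.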

Compound 3, half-maximal inhibitory concentration: 1 nM
Beside the measured number, compound 3's estimate is 15-fold (1.18 log units) above it; the measured number lies below the stated range.
By their numbers in this assay, from the lowest: compound 3; then compound 2; then compound 1.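

Amino in place of trifluoromethyl on this aromatic carbon, para to a large group, gives an 11-fold lower number from compound 1 to compound 3 (1.04 log units; beyond the scatter) in this assay and so shows that potency in the series is sensitive to the group at this position. The change is large and comes with fewer heavy atoms plus a hydrogen-bond donor and acceptor, and this single pair cannot separate these differences. No measurement bears on the reason for the step.

Whether the free amino group is needed remains open, since methylamino, acetamido and hydroxyl at this carbon are not among the compounds shown. Also open, on these data alone, is whether the same change would carry over to the core of compound 2.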